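Benzyl-to-chloropyridinylmethyl swap in a weak cytotoxic series

The source may hold more compounds than are shown below. What is called first, only, known or untested is meant among the compounds shown, and "the series" means these compounds.

Both measured compounds sit at limits in a functional assay on SV5A8 cells (Homo sapiens) for cytotoxicity; on this read-out lower numbers stand for stronger inhibition and higher numbers for weaker inhibition. Compound 1 `Cc1ccc2c(NCc3ccc(NC(=O)C4CCN(Cc5cccc(F)c5)CC4)cc3)nc(N(C)C)nc2c1` gives in this assay only > 4170 nM, a limit of the assay rather than a number. Compound 2 `CCN1CCN(c2nc(NCc3ccc(NC(=O)C4CCN(Cc5ccccc5)CC4)cc3)c3ccc(C)cc3n2)CC1` gives in this assay only > 13000 nM, likewise a limit. Compound 1 therefore stands at one of two limits shown the limit of > 4170 nM in this assay, at which 1 of the 2 values shown sits (the limit of > 13000 nM in this assay, at which 1 of the 2 values shown sits). Compound 3 `Cc1ccc2c(NCc3ccc(NC(=O)C4CCN(Cc5cc(Cl)ccn5)CC4)cc3)nc(N(C)C)nc2c1` differs from compound 1 by 4-chloropyridin-2-yl in place of 3-fluorophenyl on a saturated chain carbon bound to an amine nitrogen in a ring, on a saturated chain carbon bound to an amine nitrogen in a ring. Among the compounds with values here, no measured step covers this change. The step from compound 1 to compound 3 in this assay is expected at a step that the limit leaves unreadable from compound 1 to compound 3, none beyond the scatter. Compound 3 is estimated at 8000 nM, ranging from 2000 nM to 40000 nM, most likely again reported as a limit.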

Compound 3, half-maximal inhibitory concentration: > 5400 nM
Compound 3 ended at the assay's limit; the forecaster's own chance of this, stated with the estimate: 80%; the middle value does not contradict the limit.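

In this assay, within the data shown here, compound 1 and compound 3 both stand at limits of the assay, so no step between them can be read. As far as these compounds go, whether 4-chloropyridin-2-yl in place of 3-fluorophenyl shifts the read-out at all stays open.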